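Adding a Third Methoxy to the Ketone-Side Ring

The source may hold more compounds than are shown below. What is called first, only, known or untested is meant among the compounds shown, and "the series" means these compounds.

Two measured compounds share a pyrazole-linked chalcone-like core. Compound 1 `COc1ccc(-c2cc(/C=C/C(=O)c3cc(OC)c(OC)c(OC)c3)[nH]n2)cc1OC` and compound 2 `COc1ccc(C(=O)/C=C/c2cc(-c3cc(OC)c(OC)c(OC)c3)n[nH]2)cc1OC` were both tested in a functional assay on MDA-MB-435 cells (Homo sapiens) for cytotoxicity, read by sulforhodamine B assay, with a stated time of 48 h, tested at 10 uM; on this read-out lower numbers stand for a stronger effect and higher numbers for a weaker effect at the one concentration tested. In this assay compound 1 gives -55%, while compound 2 gives -92%. Compound 2 therefore has the lowest of the two numbers, with compound 1 standing a good deal higher, a gap beyond the usual scatter.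

Compound 3 `COc1cc(C(=O)/C=C/c2cc(-c3cc(OC)c(OC)c(OC)c3)n[nH]2)cc(OC)c1OC` has not yet been measured. It differs from compound 2 in a single place: methoxy in place of hydrogen on an aromatic carbon. Because compound 2 already gives -92%, a value near the bottom of the scale, little room remains for a further fall, and no step beyond the scatter is expected from compound 2 to compound 3. The expected step of a number 4 percentage points higher from compound 2 to compound 3 (within the scatter) is therefore small. Compound 3 is expected to give -88%, within a range from -100% to -60%.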

Compound 3, a percentage reported as activity, at one concentration (the size of the read-out at that concentration, not a potency): -90%
Estimate against measurement, compound 3: 2 percentage points above, and the stated range covers the measured number.
By their numbers in this assay, from the lowest: compounds 2 and 3 (each within the scatter of the next); then compound 1.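

Among the compounds shown here, on the ketone-side ring, methoxy in place of hydrogen gives no step that stands out in this assay: a number 2 percentage points higher from compound 2 to compound 3 (within the scatter). The same swap on the other aromatic ring gives a large step, a number 35 percentage points lower from compound 1 to compound 3 (beyond the scatter), so compound 3 shows that the effect of this one change depends on which ring carries it. Nothing measured here explains that contrast.

Compound 2 and compound 3 both lie near the bottom of the scale, so a single concentration cannot show whether they would still differ under conditions that leave more room to separate them. Going by these compounds, it also remains open how a smaller or different group at this carbon, such as a hydroxyl, an amine or a longer ether chain, would behave in this assay.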